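A few compounds are considered here, and "the series" means these few. Any claim that something is new, unique, unknown or untested is made for them only; others in the source may bear on it.

Compound 1, `Cc1nc(N)sc1CCCN/C(N)=N/C(=O)NC(C)c1ccc(Br)cc1`, sits second highest among the three values recorded in a functional assay on Right cardiac atrium for agonist activity at histamine H2 receptor (Cavia porcellus), with a stated time of 30 min, in the presence of a further agent that is not named here (a lower number here means that less compound is needed, a higher number that more compound is needed for the effect), where compound 1 gives 55 nM. Compound 3, `CCCCCCNC(=O)/N=C(\N)NCCCc1sc(N)nc1C`, gives 15.9 nM in this assay, a lower number that lies beyond the usual scatter, while compound 2, `Cc1nc(N)sc1CCCN/C(N)=N/C(=S)N[C@@H](C)c1ccccc1`, gives 224 nM, a higher number that also lies beyond it. Compound 4, `Cc1nc(N)sc1CCCN/C(N)=N/C(=O)NC(C)c1cccc(F)c1`, differs from compound 1 in one place: 3-fluorophenyl in place of 4-bromophenyl on a saturated chain carbon bound to an amide-type nitrogen and a saturated chain carbon. For the measured compounds named here, no pair of measured compounds shows a change of this kind, so there is no measured step to lean on. The expected step is small, a 1.3-fold higher number from compound 1 to compound 4 (0.10 log units; within the scatter), with no clear direction beyond the scatter. For compound 4 the estimated value in this assay is 70 nM, expected to fall between 25 nM and 200 nM.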

Compound 4, half-maximal effective concentration: 26.3 nM
The estimate for compound 4 lay 2.7-fold (0.43 log units) above the measured number, and the stated range covers the measured number.
By their numbers in this assay, from the lowest: compounds 3 and 4 (each within the scatter of the next); then compound 1; then compound 2.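

In this assay, for the compounds shown here, the change of 4-bromophenyl to 3-fluorophenyl gives a 2.1-fold lower number from compound 1 to compound 4 (0.32 log units; beyond the scatter) as the first measured step at this place. The bromine is therefore not required for agonist activity, and the modest step favours 3-fluorophenyl. Nothing measured here gives a reason for this shift.

On these data alone, the halogen and its place on the ring change together, so their separate contributions stay unknown. As far as these compounds go, it also remains open how 3-bromophenyl, or a phenyl ring carrying an amine or a carboxylic acid, would behave here.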